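The source may report more compounds than this note shows. Statements on the series, on what has been measured and on what is new or still open speak of the compounds shown alone.

Three compounds have been run in a functional assay on the whole organism with Mus musculus as the target, in the forced swim test, with stated times of 1 h and 5 min, at a dose of 10 mg/kg; on this read-out higher numbers stand for more inhibition at the one dose given (going by the name of the read-out) and lower numbers for less inhibition. Compound 1 `O=C(Nc1ccccc1)N1CCN(c2ccccc2)CC1` gives 27.7% in this assay. Compound 2 `CCOC(=O)Nc1ccccc1` gives 21.6%. Compound 3 `CCN(CC)C(=O)Nc1ccc(C(=O)O)cc1` gives 16.7%, the lowest of the three numbers, although the gap to compound 2 lies within the scatter and only the gap to compound 1 lies beyond it. Compound 4 `CCN(CC)C(=O)Nc1ccc(Cl)cc1` has not yet been measured in this assay.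

Compound 4 differs from compound 3 in one place: chloro in place of carboxy on an aromatic carbon. Going by the values given here, no step between two measured compounds tests this change, so the account rests on the three values alone. All of them sit within a narrow band, and nothing in the data points to a direction for the change from carboxy to chloro. A step of no more than the scatter, in either direction, is therefore expected from compound 3 to compound 4, namely a number 5.3 percentage points higher from compound 3 to compound 4 (within the scatter). Compound 4 is accordingly expected to give about 22% in this assay, with a range from 6% to 40%.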

Compound 4, a percentage reported as inhibition, in the whole organism at one dose (the size of the read-out at that dose, not a potency): 7.04%
Compound 4: middle estimate off by 15 percentage points, on the high side; the measured number falls inside the stated range.
By their numbers in this assay, from the lowest: compounds 4, 3, 2 and 1 (each within the scatter of the next, the first and the last beyond it).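

In this assay, going by these compounds alone, the single replacement gives a number 9.7 percentage points lower from compound 3 to compound 4 (within the scatter) and so provides the first direct test of this position, the aromatic carbon para to a group of 8 heavy atoms. Chloro takes the place of carboxy here, so a hydrogen-bond donor, a hydrogen-bond acceptor and two heavy atoms are lost without a change beyond the scatter, and the read-out at this one dose does not show that carboxy is required. No measurement at hand explains this result.

An amine or a methoxy group on the same aromatic carbon would test whether other replacements also stay within the scatter of compound 3. A longer chain in place of the ethyl groups would show whether the other end of the molecule matters more than this position.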